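The source may hold more compounds than are shown below. What is called first, only, known or untested is meant among the compounds shown, and "the series" means these compounds.

Measured compounds in a functional assay on SW480 cells (Homo sapiens) for antiproliferative activity, read by MTT assay, with a stated time of 48 h; a lower number here means a stronger inhibitor, a higher number a weaker inhibitor:
- compound 1 `O=c1cc(-n2cc(COc3ccccc3Br)nn2)c2cc(Br)ccc2o1` gives 20100 nM
- compound 2 `O=c1cc(-n2cc(COc3ccccc3O)nn2)c2cc(Br)ccc2o1` gives 19100 nM
- compound 3 `CCc1ccc(OCc2cn(-c3cc(=O)oc4ccc(Br)cc34)nn2)cc1` gives 10800 nM

Compound 3 carries the lowest of the three numbers in this assay, but its nearest neighbour is compound 2, with a gap of a 1.8-fold lower number from compound 2 to compound 3 (0.25 log units; within the scatter), and its furthest is compound 1, with a gap of a 1.9-fold lower number from compound 1 to compound 3 (0.27 log units; within the scatter); both gaps lie within the scatter, so no ordering among the three is established. Compound 4 `O=c1cc(-n2cc(COc3ccc(Br)cc3)nn2)c2cc(Br)ccc2o1` has not yet been measured. It differs from compound 3 by bromo in place of ethyl on an aromatic carbon. Going by the values given here, the steps that bear on this change are those that alter the aryl group on the oxygen on a saturated carbon: a 1.9-fold lower number from compound 1 to compound 3 (0.27 log units; within the scatter) and a 1.8-fold lower number from compound 2 to compound 3 (0.25 log units; within the scatter), neither of which moved the number beyond the scatter, while a 1.1-fold lower number from compound 1 to compound 2 (0.02 log units; within the scatter) changed a substituent on that same ring with likewise no effect beyond the scatter. Compound 4 is therefore expected to show a step of a 1.3-fold higher number from compound 3 to compound 4 (0.11 log units; within the scatter), within the scatter. The estimate for compound 4 is 14000 nM, with a range from 6000 nM to 35000 nM.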

Compound 4, half-maximal inhibitory concentration: 1310 nM
Compound 4: the middle estimate sits 11-fold (1.03 log units) above what was measured, and the stated range ends above it.
By their numbers in this assay, from the lowest: compound 4; then compounds 3, 2 and 1 (each within the scatter of the next).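

Among the aryl changes on the oxygen-linked carbon, the earlier steps all stayed within the scatter, whereas in this assay bromo in place of ethyl, para to a large group, gives an 8.2-fold lower number from compound 3 to compound 4 (0.92 log units; beyond the scatter) and so shows that this position can respond to the substituent it carries. The bromo's place on the ring also counts: 4-bromophenyl in place of 2-bromophenyl gives a 15-fold lower number from compound 1 to compound 4 (1.19 log units; beyond the scatter), and 4-bromophenyl in place of 2-hydroxyphenyl gives a 15-fold lower number from compound 2 to compound 4 (1.16 log units; beyond the scatter) as a step of similar size. No measurement at hand accounts for these steps.

Only ethyl and bromo stand at this place in the compounds shown, so what chloro, an amine or a carboxylic acid would do there stays open. Every compound shown also carries the bromo on the shared core, and whether the step depends on it is likewise open.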